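Removing the Nitro Group: From Compound 2 to Compound 3

This account rests on a few compounds, and the source may have more. Where it says the series, first, only, none or still open, it means among the compounds named here.

Compound 1 `CC1=NC(C)=C(C(=O)O)C(c2ccccc2[N+](=O)[O-])/C1=C(\O)OC/C=C/c1ccccc1` gives 31 nM.
Compound 2 `CC1=NC(C)=C(C(=O)O)C(c2ccc([N+](=O)[O-])cc2)/C1=C(\O)OC/C=C/c1ccccc1` gives 1600 nM.

Both numbers come from a functional assay on thoracic aorta for inhibition of Voltage-gated L-type calcium channel (Rattus norvegicus); on this read-out lower numbers stand for stronger inhibition and higher numbers for weaker inhibition. For the measured compounds named here, compound 2 stands at the highest of the two numbers, so it is the weaker inhibitor of the pair; the one measured step, a 52-fold higher number from compound 1 to compound 2 (1.71 log units; beyond the scatter), is large and lies well beyond the scatter.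

Compound 3 `CC1=NC(C)=C(C(=O)O)C(c2ccccc2)/C1=C(\O)OC/C=C/c1ccccc1` has not yet been measured. It differs from compound 2 by hydrogen in place of nitro on an aromatic carbon. Going by the values given here, the measured step of a 52-fold higher number from compound 1 to compound 2 (1.71 log units; beyond the scatter) concerns only where the nitro group sits on that ring, not its removal, so it bears on this change only loosely: it shows that this read-out reacts strongly to changes on that ring, but no measured compound lacks the nitro group altogether. A modest step toward higher numbers, a 1.6-fold higher number from compound 2 to compound 3 (0.19 log units; within the scatter), is therefore expected for compound 3, possibly within the scatter. In this assay compound 3 is estimated at 2500 nM, with a range from 700 nM to 9000 nM.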

Compound 3, half-maximal inhibitory concentration: 9 nM
Estimate against measurement, compound 3: 280-fold (2.44 log units) above, and the stated range ends above it.
By their numbers in this assay, from the lowest: compound 3; then compound 1; then compound 2.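

In this assay, the nitro group turns out not to be needed for inhibition, since replacing it with hydrogen lowers the number whichever nitro compound is the starting point. The size of that gain depends heavily on where the nitro group sat, with a 180-fold lower number from compound 2 to compound 3 (2.25 log units; beyond the scatter) against only a 3.4-fold lower number from compound 1 to compound 3 (0.54 log units; beyond the scatter) for the same replacement. Compound 3, with no substituent on this phenyl ring, is therefore the strongest inhibitor of the three, and nothing available explains these differences in size.

The compounds shown carry only nitro or hydrogen on this ring, so it remains open whether a chlorine atom, a methoxy group or an amine would keep the number as low as in compound 3. It is also unknown whether the same order would hold with a methyl group in place of the long phenyl-ending chain on the shared core.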